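Isopropyl for methyl on a fused imidazole nitrogen

A few compounds are considered here, and "the series" means these few. Any claim that something is new, unique, unknown or untested is made for them only; others in the source may bear on it.

Two compounds in this set share a core built from a fused five-membered aromatic ring carrying two nitrogens, linked through a double bond to a sulfur-containing ring that bears an amide-tipped side chain. Compound 1 `CC(C)n1c(/C=C2\SC(=O)N(CC(=O)N3CCCCC3)C2=O)nc2ccccc21` carries a piperidine amide on that chain. Compound 2 `CC1CN(C(=O)CN2C(=O)S/C(=C\c3nc4ccccc4n3C)C2=O)CC(C)O1` carries a dimethylmorpholine amide instead and a methyl on the aromatic nitrogen. In a functional assay on PC-3 cells (Homo sapiens) for inhibition, read by MTT assay, with a stated time of 48 h (on this read-out higher numbers stand for weaker inhibition and lower numbers for stronger inhibition), compound 1 gives only a limit of the assay, > 50000 nM. In this assay compound 2 likewise gives only a limit, > 50000 nM. Compound 2 therefore stands at the limit that both values share, (the limit of > 50000 nM in this assay, at which 2 of the 2 values shown sit), and no numerical ranking between the two is available.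

Compound 3 `CC1CN(C(=O)CN2C(=O)S/C(=C\c3nc4ccccc4n3C(C)C)C2=O)CC(C)O1` differs from compound 2 in one place: isopropyl in place of methyl on an aromatic nitrogen. For the measured compounds named here, no measured pair isolates this change. Since compound 1 already carries the isopropyl and gives > 50000 nM, no step beyond the scatter is expected from compound 2 to compound 3, a step that the limit leaves unreadable from compound 2 to compound 3. Compound 3 is accordingly estimated to give 80000 nM in this assay, within a range of 30000 nM to 300000 nM, most likely reported again only as a limit.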

Compound 3, half-maximal inhibitory concentration: > 50000 nM
Compound 3: only a limit was reported; the forecaster's own chance of this, stated with the estimate: 80%; the middle value lies beyond the limit too.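

In this assay compound 3 gives only a limit, > 50000 nM. The steps to it from compound 1 and from compound 2 cannot be read, and all three compounds stand together: the limit of > 50000 nM in this assay, at which 3 of the 3 values shown sit. The compounds shown leave open whether exchanging methyl for isopropyl, or piperidin-1-yl for 2,6-dimethylmorpholin-4-yl, changes inhibition in this assay at all.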